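The source may report more compounds than this note shows. Statements on the series, on what has been measured and on what is new or still open speak of the compounds shown alone.

Measured so far in an ADME assay for pharmacokinetics, in simulated intestinal fluid; a higher number here means that the compound lasts longer, a lower number that the compound disappears faster:

Compound 1 `CCOc1cc(NC(=O)C2(NC(=O)c3ccc4c(C5CCCC5)c(-c5ncc(Cl)cn5)n(C)c4c3)CCC2)ccc1/C=C/C(=O)N[C@@H](CC(=O)O)C(N)=O` gives 0.0667 h in this assay.
Compound 2 `CCOC(=O)/C=C/c1ccc(NC(=O)C2(NC(=O)c3ccc4c(C5CCCC5)c(-c5ncc(Cl)cn5)n(C)c4c3)CCC2)cc1OCC` reaches only the limit > 5 h in this assay; this is a limit of the assay, not a number.
Compound 3 `CCOc1cc(NC(=O)C2(NC(=O)c3ccc4c(C5CCCC5)c(-c5ncc(Cl)cn5)n(C)c4c3)CCC2)ccc1/C=C/C(=O)OCC(Cl)(Cl)Cl` likewise reaches only the limit > 5 h in this assay.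

Compound 3 thus stands at the limit, together with one other value, as recorded in the limit of > 5 h in this assay, at which 2 of the 3 values shown sit. The two readable steps are an at least 74-fold higher number from compound 1 to compound 2 (1.87 log units; beyond the scatter) and an at least 74-fold higher number from compound 1 to compound 3 (1.87 log units; beyond the scatter), both changes on the carbonyl carbon. The step that the two limits leave unreadable from compound 2 to compound 3 lies at the same place as the change now in question but cannot be read, because both ends sit at the limit.

Compound 4 `CCOc1cc(NC(=O)C2(NC(=O)c3ccc4c(C5CCCC5)c(-c5ncc(Cl)cn5)n(C)c4c3)CCC2)ccc1/C=C/C(=O)OCC(=O)N1CCOCC1` differs from compound 3 by (morpholin-4-yl)carbonyl in place of trichloromethyl on a saturated chain carbon bound to an oxygen next to a carbonyl group. Within the data shown here, no measured step bears directly on this change; only the unreadable one touches the same place. Given (the limit of > 5 h in this assay, at which 2 of the 3 values shown sit), compound 4 is expected to sit at or near the limit again, i.e. the estimated step of an at least 1.2-fold lower number from compound 3 to compound 4 (0.09 log units; that floor lies within the scatter) is taken as small. Compound 4 is therefore estimated at 4 h in this assay, with a range from 1 h to 8 h.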

Compound 4, half-life: 3.17 h
For compound 4 the middle estimate is 1.3-fold (0.10 log units) above the measured one, within the range that was stated.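

In this assay compound 4 gives 3.17 h, a number and not a limit, so with (morpholin-4-yl)carbonyl on a saturated chain carbon bound to an oxygen next to a carbonyl group, this position now has a readable value. The comparisons with the trichloromethyl and methyl groups are only floors, an at least 1.5-fold lower number from compound 3 to compound 4 (0.19 log units; that floor lies within the scatter) and an at least 1.5-fold lower number from compound 2 to compound 4 (0.19 log units; that floor lies within the scatter), set by the limit: the limit of > 5 h in this assay, at which 2 of the 4 values shown sit. Among these compounds, with ((morpholin-4-yl)carbonyl)methoxy in place of (1-carbamoyl-2-carboxyethyl)amino on a carbonyl carbon, the series shows a 48-fold higher number from compound 1 to compound 4 (1.68 log units; beyond the scatter), the first large step here with a number at both ends.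

From the compounds shown here alone, whether compound 4 truly differs from compound 2 or compound 3 remains open, and the step between those two cannot be read. Also open, going by these compounds, is how a primary amine or a carboxylic acid at this same place would read in this assay.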